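Swapping chloro for tert-butyl on a benzanilide

The source may report more compounds than this note shows. Statements on the series, on what has been measured and on what is new or still open speak of the compounds shown alone.

Measured compounds:
compound 1 `C[C@@H]1CN(c2ncccc2C(F)(F)F)CCN1C(=O)Nc1ccc(C(F)(F)F)cc1` gives 17 nM
compound 2 `Cc1cccnc1-c1ccc(C(=O)Nc2ccc(Cl)cc2)cc1` gives 1500 nM

Of the compounds shown here, two have been measured in a functional assay for antagonist activity at transient receptor potential cation channel subfamily V member 1 (Homo sapiens), read by FLIPR; a higher number here means a weaker inhibitor, a lower number a stronger inhibitor. Compound 1 is built on a urea core, while compound 2 carries an amide between two aromatic rings. Of the two numbers, compound 2 stands at the higher one; compound 1 sits at a much lower value, and that gap lies well beyond the usual scatter. The two cores differ in many places, so the gap cannot be attributed to any single change.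

For the measured compounds named here, compound 3 `Cc1cccnc1-c1ccc(C(=O)Nc2ccc(C(C)(C)C)cc2)cc1` keeps the core of compound 2 and changes only one group: tert-butyl in place of chloro on an aromatic carbon. Going by the values given here, no measured pair shows what this exchange does, so the expectation rests on the change alone. A modest gain in potency is expected, that is a step downward in this assay somewhat beyond the scatter, given by a 3.8-fold lower number from compound 2 to compound 3 (0.57 log units; beyond the scatter). Compound 3 is estimated at 400 nM, with a range from 100 nM to 1500 nM.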

Compound 3, half-maximal inhibitory concentration: 11 nM
Compound 3: the middle estimate sits 36-fold (1.56 log units) above what was measured; measured number below the stated range.
By their numbers in this assay, from the lowest: compounds 3 and 1 (each within the scatter of the next); then compound 2.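

Exchanging chloro for tert-butyl on this aromatic carbon, para to a large group, gives a 140-fold lower number from compound 2 to compound 3 (2.13 log units; beyond the scatter) in this assay. For the compounds shown here, compounds 2 and 3 differ in this one place only, so this is the first clean reading of a single change, and it shows that this position can strongly affect potency on the shared core. No measurement available here explains why this exchange has so large an effect.

Going by these compounds, with only chloro and tert-butyl seen at this position, it remains open how groups such as methyl, isopropyl or methoxy would compare. It is also unknown whether the same exchange would bring a similar step on a different core, such as the core of compound 1.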